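The source may report more compounds than this note shows. Statements on the series, on what has been measured and on what is new or still open speak of the compounds shown alone.

Compound 1 `COc1ccc(-c2cn(Cc3ccccc3)nn2)cc1`: in a functional assay on HL-60 cells (Homo sapiens) for antiproliferative activity, read by MTT assay, with a stated time of 72 h (a lower number here means a stronger inhibitor, a higher number a weaker inhibitor), compound 1 gives > 100000 nM, which is a limit of the assay.
Compound 2 `Cc1ccc(-c2cn(Cc3ccccc3)nn2)cc1`: in this assay compound 2 gives > 100000 nM, again a limit and not a number.

Compound 2 therefore stands at the edge of what this assay reports; only a limit is known for it, and the same holds for compound 1, so that (the limit of > 100000 nM in this assay, at which 2 of the 2 values shown sit). Going by the values given here, the single measured step, a step that the two limits leave unreadable from compound 1 to compound 2, runs between two limits and its size cannot be read.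

Compound 3 `FC(F)(F)c1ccc(-c2cn(Cc3ccccc3)nn2)cc1` differs from compound 2 by trifluoromethyl in place of methyl on an aromatic carbon. Among the compounds with values here, no measured step addresses a change of this kind, and the one step that exists is unreadable, so no direction and no size can be taken from the measured compounds. With compound 2 at the limit, the step is expected to be a step that the limit leaves unreadable from compound 2 to compound 3, most likely leaving compound 3 at the same limit. Compound 3 is estimated at 150000 nM, in a range from 40000 nM to 500000 nM.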

Compound 3, half-maximal inhibitory concentration: 171000 nM
For compound 3 the middle estimate is 1.1-fold (0.06 log units) below the measured one; low and high end bracket the measured number.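

In this assay, going by these compounds alone, no step to compound 3 can be read, neither from compound 1 nor from compound 2, since both of those give only a limit: the limit of > 100000 nM in this assay, at which 2 of the 3 values shown sit. The compounds shown leave open how far methoxy, methyl and trifluoromethyl actually differ in this assay.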